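The compounds below may be only part of what the source reports. "The series", "measured", "known", "first", "only" and "open" are said of these compounds alone.

The three measured compounds share one core, seen in compound 1 `COc1ccc2c(c1)OC(c1cc(OC)c(OC)c(OC)c1)C(C(=O)NC(C)(C)C)=C2`, compound 2 `COc1ccc2c(c1)OC(c1cc(OC)c(OC)c(OC)c1)C(C(=O)N1CCCCC1)=C2` and compound 3 `CCOCC1=Cc2ccc(OC)cc2OC1c1cc(OC)c(OC)c(OC)c1`. In a functional assay for inhibition of nuclear factor NF-kappa-B complex (Homo sapiens) (on this read-out lower numbers stand for stronger inhibition and higher numbers for weaker inhibition), compound 1 gives 28400 nM. Compound 3 gives 21300 nM in this assay. For compound 2 this assay reports only a limit, > 50000 nM. Compound 2 thus stands at the limit of > 50000 nM in this assay, at which 1 of the 3 values shown sits, with no number of its own. The step of an at least 1.7-fold higher number from compound 1 to compound 2 (0.24 log units; that floor lies within the scatter) has a floor within the scatter, and a 1.3-fold lower number from compound 1 to compound 3 (0.12 log units; within the scatter) lies within it too, whereas an at least 2.3-fold lower number from compound 2 to compound 3 (0.37 log units; beyond the scatter) is at least modest.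

Compound 4 `CCCC(=O)C1=Cc2ccc(OC)cc2OC1c1cc(OC)c(OC)c(OC)c1` awaits measurement in this assay. It differs from compound 2 by propyl in place of piperidin-1-yl on a carbonyl carbon. For the measured compounds named here, the steps that bear on this change are the two that move away from compound 2, to compound 1 and to compound 3, both of which end at a number rather than a limit. Compound 4 is therefore expected to return a number as well, with a step of an at least 2.0-fold lower number from compound 2 to compound 4 (0.30 log units; that floor lies within the scatter) expected. Compound 4 is estimated at 25000 nM, within a range from 10000 nM to 60000 nM.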

Compound 4, half-maximal inhibitory concentration: 11700 nM
Compound 4: the middle estimate sits 2.1-fold (0.33 log units) above what was measured; the range from low to high includes it.
By their numbers in this assay, from the lowest: compounds 4, 3 and 1 (each within the scatter of the next, the first and the last beyond it). At a limit, above all of these: compound 2.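

Propyl in place of piperidin-1-yl on a carbonyl carbon brings an at least 4.2-fold lower number from compound 2 to compound 4 (0.63 log units; beyond the scatter), and that step is only a floor, because compound 2 has a limit and no number of its own: the limit of > 50000 nM in this assay, at which 1 of the 4 values shown sits.

Propyl in place of (tert-butyl)amino on the same carbon brings a 2.4-fold lower number from compound 1 to compound 4 (0.39 log units; beyond the scatter), the first step from compound 1 in this assay that is shown to go beyond the scatter. Propylcarbonyl in place of ethoxymethyl on a double-bonded ring carbon gives a 1.8-fold lower number from compound 3 to compound 4 (0.26 log units; within the scatter), so compound 3 and compound 4 cannot be told apart.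

The compounds shown leave open how large the step from piperidin-1-yl really is. They also leave open whether a longer chain such as butyl, or a phenyl group, on the carbonyl carbon would give a number that differs from that of compound 4 beyond the scatter.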